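From 4-Ethoxyphenyl to 3-Methoxyphenyl on the Amine Nitrogen

The source may report more compounds than this note shows. Statements on the series, on what has been measured and on what is new or still open speak of the compounds shown alone.

Compound 1, `Cc1ccc(NC2=CC(=O)c3c(nc4n3[C@H]3OC[C@@H](O)[C@H]3OC4)C2=O)cc1`: in a functional assay on MCF7 cells (Homo sapiens) for inhibition, read by sulforhodamine B assay (on this read-out higher numbers stand for weaker inhibition and lower numbers for stronger inhibition), compound 1 reaches only a limit, > 4000 nM.
Compound 2, `O=C1C=C(NC2CCCC2)C(=O)c2c1nc1n2[C@H]2OC[C@@H](O)[C@H]2OC1`: in this assay compound 2 likewise reaches only a limit, > 16000 nM.
Compound 3, `CCOc1ccc(NC2=CC(=O)c3nc4n(c3C2=O)[C@H]2OC[C@@H](O)[C@H]2OC4)cc1`: in this assay compound 3 gives 1430 nM.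

Among the measured compounds shown here, compound 3 therefore stands as the only compound with a number in this assay; the other two sit at limits of the assay, one at the limit of > 16000 nM in this assay, at which 1 of the 3 values shown sits, and one at the limit of > 4000 nM in this assay, at which 1 of the 3 values shown sits. For the measured compounds named here, the single measured step is an at least 11-fold lower number from compound 2 to compound 3 (1.04 log units; beyond the scatter), a large gain in inhibition when an aromatic group replaces an aliphatic one on the amine nitrogen.

Compound 4, `COc1cccc(NC2=CC(=O)c3nc4n(c3C2=O)[C@H]2OC[C@@H](O)[C@H]2OC4)c1`, differs from compound 3 by 3-methoxyphenyl in place of 4-ethoxyphenyl on an amine nitrogen. Going by the values given here, no measured step exchanges one aromatic group for another, so the step from compound 2 to compound 3 bears only loosely on this change: it shows that an aromatic group on the amine nitrogen can carry activity, but says nothing about where the alkoxy group sits or how long it is. The limit of compound 1 shows that not every aromatic group keeps the number seen for compound 3.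

Compound 4 is thus expected to stay within the scatter of compound 3 or to drift weaker, a step of a 1.7-fold higher number from compound 3 to compound 4 (0.24 log units; within the scatter). The estimate for compound 4 is 2500 nM, with a range from 800 nM to 8000 nM.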

Compound 4, half-maximal inhibitory concentration: > 4000 nM
Compound 4: no number, only a limit; the forecaster's own chance of this, stated with the estimate: 25%; middle value at least 1.6-fold (0.20 log units) away from the limit.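

In this assay, among the compounds shown here, replacing 4-ethoxyphenyl with 3-methoxyphenyl on the amine nitrogen gives an at least 2.7-fold higher number from compound 3 to compound 4 (0.44 log units; beyond the scatter), the first readable exchange of one aromatic group for another at this position. For the compounds shown here, the earlier step from cyclopentyl showed only that an aromatic group here can carry activity, whereas this one shows that a second alkoxy-bearing aromatic group does not keep the number of compound 3. Compound 3 remains the only compound with a number, and compound 4 reaches only a limit, the same one as compound 1: the limit of > 4000 nM in this assay, at which 2 of the 4 values shown sit.

The names 4-ethoxyphenyl and 3-methoxyphenyl differ both in where the alkoxy group sits and in its chain, and the compounds shown do not separate these two differences. They also do not tell what a longer chain on that oxygen or an amine in its place would give, and the step from compound 2 to compound 4 joins two limits and cannot be read.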